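The compounds below may be only part of what the source reports. "The series", "measured", "known", "first", "only" and "open" are said of these compounds alone.

Compounds measured so far:
- compound 1 `O=C1CC(c2ccccc2)Nc2ccccc21`: 0.13 ug/mL
- compound 2 `COc1cccc(C2CC(=O)c3ccccc3N2)c1`: 0.32 ug/mL
- compound 3 `COc1cccc([C@H]2CC(=O)c3ccccc3N2)c1`: 0.6 ug/mL

In a functional assay on MCF7 cells (Homo sapiens) for cytotoxicity, read by sulforhodamine B assay (on this read-out lower numbers stand for an effect already at smaller amounts and higher numbers for an effect only at larger amounts of compound), compound 2 gives 0.32 ug/mL, and this is the starting point for the comparison. Its closest neighbour on the numbers is the drawn stereoisomer: a 1.9-fold higher number from compound 2 to compound 3 (0.27 log units; within the scatter). That pair differs only in the fact that one of compounds 2 and 3 is drawn with a defined configuration and the other without, at the place where they differ, so it says little about a new substituent. The unsubstituted parent lies further away, beyond the scatter: a 2.5-fold higher number from compound 1 to compound 2 (0.39 log units; beyond the scatter).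

The next compound, compound 4 `COc1cccc(C2CC(=O)c3cc(N4CCCC4)ccc3N2)c1`, has not yet been measured. It carries pyrrolidin-1-yl in place of hydrogen on an aromatic carbon. Within the data shown here, no measured compound has any group at this place, so the evidence is indirect. Among the measured compounds shown here, the only measured step that adds a group to an aromatic carbon is the modest methoxy step from the parent, and it is a small group on a different part of the molecule. That step gives a rough size for such a change but no direction for this one. The larger group could move the number either way, so no shift beyond the scatter is expected, though with wide uncertainty. The step expected here is estimated as a 1.1-fold lower number from compound 2 to compound 4 (0.03 log units; within the scatter). In this assay the estimate for compound 4 is 0.3 ug/mL, with an expected range from 0.06 ug/mL to 1.5 ug/mL.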

Compound 4, concentration for half-maximal effect: 0.11 ug/mL
Estimate against measurement, compound 4: 2.7-fold (0.44 log units) above, and the stated range covers the measured number.
By their numbers in this assay, from the lowest: compounds 4 and 1 (each within the scatter of the next); then compounds 2 and 3 (each within the scatter of the next).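

Among these compounds, the step of a 2.9-fold lower number from compound 2 to compound 4 (0.46 log units; beyond the scatter) in this assay is the first reading of any group at this place, on an aromatic carbon of the six-membered ring of carbon only, meta to a fused ring and para to a fused ring, and it shows that pyrrolidin-1-yl, with its 5 heavy atoms and one five-membered non-aromatic ring, goes with a lower number here and not a higher one. Among the compounds shown here, the only earlier step that adds a group to an aromatic carbon, a 2.5-fold higher number from compound 1 to compound 2 (0.39 log units; beyond the scatter), runs the opposite way, but it is a methoxy group on a different part of the molecule, so the two steps show that the direction of such a change is not the same in these two cases. Nothing in the information at hand speaks to why the number falls with this change.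

On these data alone, what remains open is whether the shift belongs to the ring of pyrrolidin-1-yl or to its nitrogen, which a dimethylamino group, a morpholine or a plain methoxy group at the same place would help to separate. As far as these compounds go, it is also open whether pyrrolidin-1-yl has a similar effect on the core of compound 1, without the methoxy group.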